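A chloro-for-hydroxy swap on a thiosemicarbazone hydrazone

The source may report more compounds than this note shows. Statements on the series, on what has been measured and on what is new or still open speak of the compounds shown alone.

Measured in a functional assay on K562 cells (Homo sapiens) for inhibition, read by sulforhodamine B assay, with a stated time of 48 h; on this read-out lower numbers stand for stronger inhibition of growth and higher numbers for weaker inhibition of growth:
compound 1, `CC1=CC[C@H](C(C)(C)NC(=S)NN)CC1`, a limit of the assay at > 100000 nM
compound 2, `CC1=CC[C@H](C(C)(C)NC(=S)N/N=C/c2ccc(O)cc2)CC1`, a limit of the assay at > 100000 nM
compound 3, `CC1=CC[C@H](C(C)(C)NC(=S)N/N=C/c2ccc(N(C)C)cc2)CC1`, 22600 nM

Compound 2 gives no number in this assay, only a limit, and it shares that position with one other compound, so it stands at the weak end of what is shown (the limit of > 100000 nM in this assay, at which 2 of the 3 values shown sit). The unmeasured compound 4, `CC1=CC[C@H](C(C)(C)NC(=S)N/N=C/c2cccc(Cl)c2)CC1`, differs from it by 3-chlorophenyl in place of 4-hydroxyphenyl on a carbon with a double bond to nitrogen. Within the data shown here, the only measured step that bears on a change at this aryl ring is an at least 4.4-fold lower number from compound 2 to compound 3 (0.64 log units; beyond the scatter), which shows that replacing the hydroxy there can move the number out of the limit by a modest amount. The change to the 3-chlorophenyl group is a different substitution, so compound 4 is expected to land somewhere between the limit of compound 2 and the value of compound 3, with the step of an at least 2.2-fold lower number from compound 2 to compound 4 (0.34 log units; beyond the scatter) expected. Compound 4 is therefore estimated at 45000 nM, within 15000 nM to 150000 nM, and it may again report only a limit.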

Compound 4, concentration for 50% growth inhibition: 5400 nM
Compound 4: middle estimate off by 8.3-fold (0.92 log units), on the high side; measured number below the stated range.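

In this assay, among these compounds, the aryl group on the carbon with a double bond to nitrogen turns out to allow far more than the earlier compounds showed: 3-chlorophenyl in place of 4-hydroxyphenyl gives an at least 18-fold lower number from compound 2 to compound 4 (1.26 log units; beyond the scatter). Among the compounds shown here, compound 3 reads 22600 nM and compound 4 reads 5400 nM, so the lowest printed number so far comes from a ring group with no hydrogen-bond donors or acceptors, not from the dimethylamino-bearing ring. The step starts from a limit, not a number, for compound 2: the limit of > 100000 nM in this assay, at which 2 of the 4 values shown sit.

The compounds shown leave open whether the chlorine or the loss of the hydroxy carries this step, as a plain phenyl, bromo or methoxy ring is not among them. They also leave open how a different group at the other end of the shared core, such as an amine, would read.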